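Hydroxyphenyl isomer swap in a three-aryl series

The compounds below may be only part of what the source reports. "The series", "measured", "known", "first", "only" and "open" are said of these compounds alone.

Compound 2 `Oc1cccc(-c2cc(-c3ccsc3)cc(-c3ccccc3O)n2)c1` is the lower of the two measured compounds in an assay on isolated protein for inhibition of DNA topoisomerase 1 (Homo sapiens), with a stated time of 30 min, tested at 100 uM (a higher number here means a stronger effect of the compound at the concentration tested, a lower number a weaker effect), giving 10.2%. Compound 1 `Oc1cccc(-c2cc(-c3cccs3)cc(-c3cccc(O)c3)n2)c1` gives 91.7% in this assay, a gap beyond the scatter. Compound 3 `Oc1cccc(-c2cc(-c3ccsc3)cc(-c3cccc(O)c3)n2)c1` has not been measured; it differs from compound 2 by 3-hydroxyphenyl in place of 2-hydroxyphenyl on an aromatic carbon. Among the compounds with values here, no step between measured compounds is available for this change. A large rise is expected, with the step from compound 2 to compound 3 estimated at a number 64.8 percentage points higher from compound 2 to compound 3 (beyond the scatter). Because compound 1, which carries the 3-hydroxyphenyl group at that place, gives 91.7%, compound 3 is estimated at 75%, within 40% to 95%.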

Compound 3, a percentage reported as inhibition, at one concentration (the size of the read-out at that concentration, not a potency): 59.2%
For compound 3 the middle estimate is 15.8 percentage points above the measured one; measured number inside the range.
By their numbers in this assay, from the lowest: compound 2; then compound 3; then compound 1.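

At the aromatic carbon next to the ring nitrogen, 3-hydroxyphenyl in place of 2-hydroxyphenyl now has a direct reading in this assay, with a number 49 percentage points higher from compound 2 to compound 3 (beyond the scatter). The thiophene attachment also counts: thiophen-3-yl in place of thiophen-2-yl gives a number 32.5 percentage points lower from compound 1 to compound 3 (beyond the scatter), so the 3-hydroxyphenyl group alone does not set the read-out. Nothing available bears on the cause of either step.

Still open, as far as these compounds go, is how an amine or a carboxylic acid in place of the hydroxyl on that phenyl group would read. Also open, from the compounds shown here alone, is whether the thiophene step holds with 2-hydroxyphenyl at this position.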